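Working notes: from pyridin-3-yl to pyridin-4-yl

The compounds below may be only part of what the source reports. "The series", "measured", "known", "first", "only" and "open" are said of these compounds alone.

Measured in an ADME assay on L02 cells (Homo sapiens) for cytotoxicity, read by MTT assay, with a stated time of 24 h; on this read-out higher numbers stand for weaker inhibition and lower numbers for stronger inhibition:
- compound 1 `O=C1/C(=C/c2cccnc2)CN(S(=O)(=O)c2ccc(Br)cc2)C/C1=C\c1ccccc1F`: 14600 nM
- compound 2 `O=C1/C(=C/c2cccnc2)CN(S(=O)(=O)c2ccc(F)cc2)C/C1=C\c1ccccc1C(F)(F)F`: 16100 nM
- compound 3 `O=C1/C(=C/c2cccnc2)CN(S(=O)(=O)c2ccc(Br)cc2)C/C1=C\c1ccccc1C(F)(F)F`: 13300 nM

Compound 3, at 13300 nM, is not separated from the other two compounds, since its two steps both lie within the scatter. The next structure is compound 4 `O=C1/C(=C/c2ccncc2)CN(S(=O)(=O)c2ccc(Br)cc2)C/C1=C\c1ccccc1C(F)(F)F`, with the change (pyridin-4-yl in place of pyridin-3-yl on a double-bonded chain carbon bound to a double-bonded ring carbon). In words, this is pyridin-4-yl in place of pyridin-3-yl on a double-bonded chain carbon bound to a double-bonded ring carbon.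

Two measured steps offer indirect guidance: a 1.1-fold lower number from compound 1 to compound 3 (0.04 log units; within the scatter) for trifluoromethyl in place of fluoro, and a 1.2-fold lower number from compound 2 to compound 3 (0.08 log units; within the scatter) for bromo in place of fluoro. Both are small, but neither touches the pyridinyl group. Going by the values given here, no measured pair tests this switch, so the flat values of the three compounds are the only guide, and the uncertainty is wider than those steps suggest.

No step beyond the scatter is expected in this assay. The expected step is a 1.1-fold higher number from compound 3 to compound 4 (0.02 log units; within the scatter). For compound 4 the estimated value is 14000 nM, with an expected range of 8500 nM to 23000 nM.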

Compound 4, half-maximal inhibitory concentration: 12600 nM
Beside the measured number, compound 4's estimate is 1.1-fold (0.05 log units) above it; low and high end bracket the measured number.
By their numbers in this assay, from the lowest: compounds 4, 3, 1 and 2 (each within the scatter of the next).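

In this assay, pyridin-4-yl in place of pyridin-3-yl on a double-bonded chain carbon bound to a double-bonded ring carbon gives a 1.1-fold lower number from compound 3 to compound 4 (0.02 log units; within the scatter). Going by these compounds alone, this is the first direct reading at this position, and it shows that this change, like the trifluoromethyl and bromo changes before it, does not separate the compounds on this read-out. No supporting data are available to explain this flat result.

The compounds shown leave open whether a phenyl ring, a pyridin-2-yl group or a pyridine carrying an amine or a carboxylic acid would also stay within the scatter at this position. They also leave open whether the pyridin-4-yl change would behave the same way with fluoro in place of the bromo or the trifluoromethyl group of compound 4.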